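The source may hold more compounds than are shown below. What is called first, only, known or untested is meant among the compounds shown, and "the series" means these compounds.

In a functional assay on MCF7 cells (Homo sapiens) for cytotoxicity, read by MTT assay, with a stated time of 72 h (on this read-out lower numbers stand for stronger inhibition and higher numbers for weaker inhibition), the record so far reads as follows:

compound 1 `COc1cccc(CNC(=O)c2nc(Br)c3cccnc3c2N[C@H]2CC[C@H](N)CC2)c1` gives "not determined" (no result reported)
compound 2 `N[C@H]1CC[C@H](Nc2c(C(=O)NCc3ccc(F)cc3)nc(Br)c3cccnc23)CC1` gives 2000 nM
compound 3 `C[C@H](NC(=O)c1nc(Br)c2cccnc2c1N[C@H]1CC[C@H](N)CC1)c1ccc(F)cc1` gives "not determined" (no result reported)

Compound 3 has no single number in this assay to stand on, and compound 1 is in the same position. That leaves compound 2 at 2000 nM as the only measured reference in the set.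

The next compound is compound 4 `N[C@H]1CC[C@H](Nc2c(C(=O)NCc3ccccn3)nc(Br)c3cccnc23)CC1`, which has not yet been measured. The change (pyridin-2-yl)methyl in place of 1-(4-fluorophenyl)ethyl on an amide-type nitrogen puts (pyridin-2-yl)methyl in place of 1-(4-fluorophenyl)ethyl on an amide-type nitrogen.

Going by the values given here, no measured pair in the set shows what such a change does, and without a number for compound 3 the step cannot be sized from its starting point. Among the compounds with values here, the expectation in this assay therefore leans on the one available number, compound 2 at 2000 nM, and it is a loose one. A small step or none beyond the scatter is expected, with any move somewhat more likely toward weaker inhibition than toward stronger.

For compound 4 the estimated half-maximal inhibitory concentration is 3000 nM (expected range 1000 nM to 10000 nM).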

Compound 4, half-maximal inhibitory concentration: 15000 nM
Estimate against measurement, compound 4: 5.0-fold (0.70 log units) below; the measured number lies above the stated range.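

In this assay, going by these compounds alone, the first readable step falls on the group carried by the amide-type nitrogen: pyridin-2-yl in place of 4-fluorophenyl on a saturated chain carbon bound to that nitrogen gives a 7.5-fold higher number from compound 2 to compound 4 (0.88 log units; beyond the scatter) and thus a move toward weaker inhibition. This shows that the position is sensitive to the aromatic ring it carries, which the lone value of compound 2 could not show. Steps to or from compound 1 and compound 3 cannot be read, and nothing at hand accounts for the loss seen with compound 4.

The single step changes the ring atoms and the fluorine together, so the compounds shown leave open whether a plain phenyl on the same chain carbon would stay closer to compound 2 or to compound 4. They also leave open how pyridin-3-yl or pyridin-4-yl would compare with pyridin-2-yl, and what the extra methyl of the 1-(4-fluorophenyl)ethyl group contributes in this assay.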